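The compounds below may be only part of what the source reports. "The series", "measured", "known", "first", "only" and "open" are said of these compounds alone.

Measured so far in a functional assay on MCF7 cells (Homo sapiens) for antiproliferative activity, read by MTT assay, with a stated time of 48 h; a higher number here means a weaker inhibitor, a lower number a stronger inhibitor:
Compound 1 `COc1ccc(-c2nn(-c3ccccc3)cc2CNc2ccc(C)cc2)cc1`: 8160 nM
Compound 2 `Brc1ccc(NCc2cn(-c3ccccc3)nc2-c2ccc(Br)cc2)cc1`: 5000 nM

Going by the values given here, these are the only two numbers available. Compound 2 at 5000 nM sits within the usual scatter of compound 1 at 8160 nM, so repeated measurements could not be expected to separate them. The two compounds differ in more than one place, so they give no direct measure of any single change.

The next compound is compound 3 `Cc1ccc(NCc2cn(-c3ccccc3)nc2-c2ccc(Br)cc2)cc1`. It keeps everything in compound 2 except one group: methyl in place of bromo on an aromatic carbon. In words, this is methyl in place of bromo on an aromatic carbon, para to a large group, which turns the 4-bromophenyl into a 4-methylphenyl.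

Compound 1 also carries the (4-methylphenyl)amino group and gives 8160 nM, which offers no sign of a large shift. The expectation is therefore a small drift toward a higher number, with nothing beyond the scatter.

The estimated change is a 1.2-fold higher number from compound 2 to compound 3 (0.08 log units; within the scatter).

For compound 3, the expected value is 6000 nM, with an estimated range of 2500 nM to 14000 nM.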

Compound 3, half-maximal inhibitory concentration: 5380 nM
The estimate for compound 3 lay 1.1-fold (0.05 log units) above the measured number; the range from low to high includes it.
By their numbers in this assay, from the lowest: compounds 2, 3 and 1 (each within the scatter of the next).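

In this assay, going by these compounds alone, the first direct reading at this position comes from putting methyl in place of bromo on an aromatic carbon, para to a large group, which gives a 1.1-fold higher number from compound 2 to compound 3 (0.03 log units; within the scatter) and so shows that this particular exchange of one heavy atom for another does not separate the two compounds. A second single exchange, bromo in place of methoxy on an aromatic carbon elsewhere in the molecule, gives a 1.5-fold lower number from compound 1 to compound 3 (0.18 log units; within the scatter) and likewise stays inside what repeated measurements could distinguish, so neither site has yet produced a change that can be told from noise. No supporting measurement is available to explain either reading.

Still open, from the compounds shown here alone, is whether a group of a different kind on the same aromatic carbon, such as an amine, a carboxylic acid or a longer chain, would move the number beyond the scatter. Also open, going by these compounds, is whether the exchange of methoxy and bromo would read the same with something other than the (4-methylphenyl)amino group on the rest of the molecule.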